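Ester swap on a shared core, from pyridine to indole

The source may hold more compounds than are shown below. What is called first, only, known or untested is meant among the compounds shown, and "the series" means these compounds.

Compound 1 `CC(=O)Oc1c(C(C)C)cc2c3c1OC(=O)[C@@]31CCCC(C)(C)[C@@H]1CC2` gives 290000 nM
Compound 2 `CC(C)c1cc2c3c(c1OC(=O)c1cccnc1)OC(=O)[C@@]31CCCC(C)(C)[C@@H]1CC2` gives 296000 nM

Going by the values given here, in an ADME assay on MRC5 cells (Homo sapiens) for cytotoxicity, read by neutral red uptake, with a stated time of 24 h (a higher number here means a weaker inhibitor, a lower number a stronger inhibitor), compound 2 and compound 1, the only two compounds measured so far, lie within the scatter of each other. Compound 3 `CC(C)c1cc2c3c(c1OC(=O)CCCc1c[nH]c4ccccc14)OC(=O)[C@@]31CCCC(C)(C)[C@@H]1CC2` differs from compound 2 at one place: 3-(1H-indol-3-yl)propyl in place of pyridin-3-yl on a carbonyl carbon Here 3-(1H-indol-3-yl)propyl stands in place of pyridin-3-yl on a carbonyl carbon. Among the compounds with values here, one measured step bears on this place, pyridin-3-yl in place of methyl (a 1.0-fold higher number from compound 1 to compound 2 (0.01 log units; within the scatter)), and it stays within the scatter. That single step does not cover the entering group, so the expectation is loose. In this assay no step beyond the scatter is expected, and the estimated step is small (a 1.2-fold lower number from compound 2 to compound 3 (0.07 log units; within the scatter)). For compound 3 the estimated value is 250000 nM with an expected range from 90000 nM to 600000 nM around it.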

Compound 3, half-maximal inhibitory concentration: 54500 nM
Compound 3: the middle estimate sits 4.6-fold (0.66 log units) above what was measured, outside the stated range (below it).
By their numbers in this assay, from the lowest: compound 3; then compounds 1 and 2 (each within the scatter of the next).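

In this assay, this position on the carbonyl carbon is not indifferent to what it carries, as the earlier pyridin-3-yl for methyl step alone might have suggested: 3-(1H-indol-3-yl)propyl in place of pyridin-3-yl gives a 5.4-fold lower number from compound 2 to compound 3 (0.73 log units; beyond the scatter). Read as 2-(1H-indol-3-yl)ethyl in place of hydrogen on a saturated chain carbon bound to a carbonyl carbon, the change gives a 5.3-fold lower number from compound 1 to compound 3 (0.73 log units; beyond the scatter). Nothing available explains why the number falls with this group.

The entering group brings a saturated chain and an indole together, so the compounds shown cannot separate the two; a 3-phenylpropyl group, or a 1H-indol-3-yl group set directly on the carbonyl carbon, would pull them apart. Also open, going by these compounds, is how a longer or shorter chain to the indole, or an amine at the chain end, would read here.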